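The source may report more compounds than this note shows. Statements on the series, on what has been measured and on what is new or still open speak of the compounds shown alone.

Of the compounds shown here, three built on a shared core have been tested in an assay on isolated protein for inhibition of protein kinase C theta type (Homo sapiens), read by TR-FRET, with a stated time of 2 h; on this read-out lower numbers stand for stronger inhibition and higher numbers for weaker inhibition. Compound 1 `N#Cc1cnc(NCc2cnccc2C(F)(F)F)cc1NC[C@H]1C[C@@H](O)C1` gives 300 nM in this assay. Compound 2 `N#Cc1cnc(NCc2cncnc2C(F)(F)F)cc1N[C@H]1CC[C@@H](O)CC1` gives 450 nM, a number within the scatter of that of compound 1, so the two cannot be told apart. Compound 3 `CC1(C)C[C@H](Nc2cc(NCc3cnccc3C(F)(F)F)ncc2C#N)CC(C)(C)[C@H]1O` gives 20 nM, a much lower number than compound 1, a gap well beyond the scatter. Among the three, compound 1 thus holds the second highest number, close to compound 2 and far from compound 3.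

Compound 4 `CC1(C)[C@@H](Nc2cc(NCc3cnccc3C(F)(F)F)ncc2C#N)C[C@H]1C(N)=O` has not yet been measured. It differs from compound 1 in one place: 3-carbamoyl-2,2-dimethylcyclobutyl in place of (3-hydroxycyclobutyl)methyl on a nitrogen on an aromatic ring. The entering group, like the ring in compound 3, carries two methyl groups on the ring and sits on the nitrogen without the methyl linker that the leaving group carries in its name.

Because compound 3 gives 20 nM with a ring of related build, compound 4 is expected to move to a lower number, a step of a 3.0-fold lower number from compound 1 to compound 4 (0.48 log units; beyond the scatter) that should exceed the scatter. The estimate for compound 4 in this assay is 100 nM, with a likely range from 30 nM to 400 nM.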

Compound 4, half-maximal inhibitory concentration: 140 nM
Estimate against measurement, compound 4: 1.4-fold (0.15 log units) below, within the range that was stated.
By their numbers in this assay, from the lowest: compound 3; then compound 4; then compounds 1 and 2 (each within the scatter of the next).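

In this assay, replacing (3-hydroxycyclobutyl)methyl with 3-carbamoyl-2,2-dimethylcyclobutyl on a nitrogen on an aromatic ring gives a 2.1-fold lower number from compound 1 to compound 4 (0.33 log units; beyond the scatter), the first step shown between two compounds that differ in only one place. The step is modest but beyond the scatter, so this position accepts a group of 9 heavy atoms in place of one of 6, with a four-membered carbon ring and the counts of one hydrogen-bond donor and one acceptor kept, and the number still falls. This single step bundles several changes, namely the loss of the methyl linker, the gain of two methyl groups on the ring and the exchange of hydroxyl for carbamoyl, and no measurement here explains the shift or assigns it to any one of them.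

The compounds shown leave open how much of the step belongs to each change, a question that a 3-hydroxy-2,2-dimethylcyclobutyl group on the same nitrogen could help to separate. They also leave open how this position responds when the carbamoyl group is replaced by a carboxylic acid or an aminomethyl group on the same ring.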